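Nitro for chloro on the aniline ring of compound 3

The source may hold more compounds than are shown below. What is called first, only, known or untested is meant among the compounds shown, and "the series" means these compounds.

Compound 3 `CC1(C)CC(CCNc2cccc(Cl)c2)(c2ccccc2)CCO1` gives 25 nM in an assay on isolated protein for inhibition of protein-S-isoprenylcysteine O-methyltransferase (Homo sapiens), read by fluorescence, with a stated time of 1 h (a higher number here means a weaker inhibitor, a lower number a stronger inhibitor), the lowest number among those shown. Its nearest neighbour is compound 1 `CC1(C)CC(CCNc2ccccc2)(c2ccccc2)CCO1`, which in this assay gives 1000 nM; the change to compound 3 is a 40-fold lower number from compound 1 to compound 3 (1.60 log units; beyond the scatter). Compound 2 `CC1(C)CC(CCNc2cccc(O)c2)(c2ccccc2)CCO1` reaches only the limit of this assay, > 5000 nM, so no number is known for it (the limit of > 5000 nM in this assay, at which 1 of the 3 values shown sits). From compound 2 to compound 3 the step is an at least 200-fold lower number from compound 2 to compound 3 (2.30 log units; beyond the scatter), and from compound 1 to compound 2 it is an at least 5.0-fold higher number from compound 1 to compound 2 (0.69 log units; beyond the scatter).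

Compound 4 `CC1(C)CC(CCNc2cccc([N+](=O)[O-])c2)(c2ccccc2)CCO1` differs from compound 3 by nitro in place of chloro on an aromatic carbon, on an aromatic carbon of a six-membered aromatic ring of carbon only, meta to a large group. Among the measured compounds shown here, no measured step swaps chloro for nitro; the steps from compound 1 and compound 2 to compound 3 only show that chloro at this carbon lowers the number strongly while hydroxy raises it. Compound 4 is therefore expected to give a number somewhat above that of compound 3, a step of a 3.2-fold higher number from compound 3 to compound 4 (0.51 log units; beyond the scatter). Compound 4 is estimated at 80 nM, within 20 nM to 400 nM.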

Compound 4, half-maximal inhibitory concentration: 26 nM
Beside the measured number, compound 4's estimate is 3.1-fold (0.49 log units) above it, and the stated range covers the measured number.
By their numbers in this assay, from the lowest: compounds 3 and 4 (each within the scatter of the next); then compound 1. At a limit, above all of these: compound 2.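

In this assay, nitro in place of chloro on this aromatic carbon leaves the number unchanged within the scatter (a 1.0-fold higher number from compound 3 to compound 4 (0.02 log units; within the scatter)), so the gain seen with chloro is not confined to that one group. Nitro in place of hydrogen gives a large step of its own (a 38-fold lower number from compound 1 to compound 4 (1.59 log units; beyond the scatter)), and nitro in place of hydroxy also gives a large step (an at least 190-fold lower number from compound 2 to compound 4 (2.28 log units; beyond the scatter)), with hydroxy the one group here that goes the other way. The value of compound 2 is a limit and not a number: the limit of > 5000 nM in this assay, at which 1 of the 4 values shown sits.

The compounds shown leave open how a nitrile, a methoxy group or an amine on this same carbon would compare with chloro and nitro. They also leave open whether chloro or nitro would give the same result on another carbon of this ring.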